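The source may report more compounds than this note shows. Statements on the series, on what has been measured and on what is new or still open speak of the compounds shown alone.

Working notes on the series. The shared core is seen in compound 1 `Cc1ccc(CSc2n[nH]c(-n3[se]c4ccccc4c3=O)n2)cc1`; the compounds differ in the group on the sulfur. In an ADME assay on L929 cells (Mus musculus) for antiproliferative activity, read by CCK-8 assay, with a stated time of 48 h (a higher number here means a weaker inhibitor, a lower number a stronger inhibitor), compound 1 reaches only > 50000 nM, a limit and not a number. Compound 2 `O=c1c2ccccc2[se]n1-c1nc(SCc2ccc(Cl)cc2)n[nH]1` gives 39500 nM in this assay, and compound 3 `CC(C)Sc1n[nH]c(-n2[se]c3ccccc3c2=O)n1` gives 37100 nM. The steps of an at least 1.2-fold lower number from compound 1 to compound 2 (0.10 log units; that floor lies within the scatter) and an at least 1.3-fold lower number from compound 1 to compound 3 (0.12 log units; that floor lies within the scatter) both start from the limit of > 50000 nM in this assay, at which 1 of the 3 values shown sits, and a 1.1-fold lower number from compound 2 to compound 3 (0.03 log units; within the scatter) lies within the scatter. Compound 4 `CCCSc1n[nH]c(-n2[se]c3ccccc3c2=O)n1` is not yet measured; it differs from compound 1 by ethyl in place of 4-methylphenyl on a saturated chain carbon bound to a sulfur. Because an at least 1.3-fold lower number from compound 1 to compound 3 (0.12 log units; that floor lies within the scatter) is the nearest measured guide, compound 4 is expected to land close to compound 3 rather than at the limit. Compound 4 is estimated at 40000 nM, range 20000 nM to 80000 nM. The expected step is an at least 1.2-fold lower number from compound 1 to compound 4 (0.09 log units; that floor lies within the scatter).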

Compound 4, half-maximal inhibitory concentration: 31800 nM
Compound 4: the middle estimate sits 1.3-fold (0.10 log units) above what was measured; the measured number falls inside the stated range.
By their numbers in this assay, from the lowest: compounds 4, 3 and 2 (each within the scatter of the next). At a limit, above all of these: compound 1.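

In this assay, propyl in place of isopropyl on the sulfur gives a 1.2-fold lower number from compound 3 to compound 4 (0.07 log units; within the scatter), and the change from the 4-chlorobenzyl group gives a 1.2-fold lower number from compound 2 to compound 4 (0.09 log units; within the scatter); a straight chain, a branched chain and this benzyl group therefore cannot be told apart here. Compound 1 stands at a limit, so its step reads only as a floor, an at least 1.5-fold lower number from compound 1 to compound 4 (0.19 log units; that floor lies within the scatter), and does not separate the 4-methylbenzyl group from propyl: the limit of > 50000 nM in this assay, at which 1 of the 4 values shown sits.

Still open, on these data alone, is whether any group on the sulfur moves the number beyond the scatter. A longer chain, or a chain ending in an amine or a carboxylic acid, would bear on this.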